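A few compounds are considered here, and "the series" means these few. Any claim that something is new, unique, unknown or untested is made for them only; others in the source may bear on it.

Working notes on the series. Of the compounds shown here, three sharing one core have been measured in a functional assay on KB cells (Homo sapiens) for antiproliferative activity, read by sulforhodamine B assay, with a stated time of 3 days; a higher number here means that more compound is needed for the effect, a lower number that less compound is needed. Compound 1 `CCC1=C(O)c2c(oc(-c3ccc(C)cc3)cc2=O)C(CC)(CC)C1=O` gives 39.2 uM. Compound 2 `CCC1=C(O)c2c(oc(-c3ccc(O)cc3)cc2=O)C(CC)(CC)C1=O` gives 20.6 uM, and compound 3 `CCC1=C(O)c2c(oc(-c3ccc(OC)cc3)cc2=O)C(CC)(CC)C1=O` gives 17.7 uM. The steps are small: a 1.9-fold lower number from compound 1 to compound 2 (0.28 log units; within the scatter), a 2.2-fold lower number from compound 1 to compound 3 (0.35 log units; beyond the scatter), and a 1.2-fold lower number from compound 2 to compound 3 (0.07 log units; within the scatter). Compound 2 stands second highest of the three numbers; its nearest neighbour is compound 3 and its furthest is compound 1, both within the scatter of it.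

The next compound, compound 4 `CCC1=C(O)c2c(oc(-c3cccc(OC)c3)cc2=O)C(CC)(CC)C1=O`, is not yet measured. Against compound 2 the change is 3-methoxyphenyl in place of 4-hydroxyphenyl on an aromatic carbon. Going by the values given here, only one measured step bears on this: a 1.2-fold lower number from compound 2 to compound 3 (0.07 log units; within the scatter), which covers the methyl on the oxygen, and it stayed within the scatter. Among the compounds with values here, no measured pair covers the move of the substituent from the 4-position to the 3-position of the phenyl, so that part of the change is without precedent here. Within the data shown here, on the three numbers so far, the phenyl substituents have shifted the result little, so the step of a 1.1-fold higher number from compound 2 to compound 4 (0.03 log units; within the scatter) is expected to stay within the scatter, with no set direction. Compound 4 is therefore estimated at 22 uM in this assay, with a range of 9 uM to 55 uM.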

Compound 4, concentration for half-maximal effect: 13.3 uM
Beside the measured number, compound 4's estimate is 1.7-fold (0.22 log units) above it; the range from low to high includes it.
By their numbers in this assay, from the lowest: compounds 4, 3, 2 and 1 (each within the scatter of the next, the first and the last beyond it).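

The 3-methoxyphenyl in place of 4-methoxyphenyl on this aromatic carbon gives the first measured shift of a substituent around the phenyl in this assay, a 1.3-fold lower number from compound 3 to compound 4 (0.12 log units; within the scatter), and the exchange of 4-hydroxyphenyl, which carries a hydrogen-bond donor that 3-methoxyphenyl lacks, for 3-methoxyphenyl also stays within the scatter, a 1.5-fold lower number from compound 2 to compound 4 (0.19 log units; within the scatter). Only the exchange of 4-methylphenyl for 3-methoxyphenyl goes beyond the scatter, a 2.9-fold lower number from compound 1 to compound 4 (0.47 log units; beyond the scatter), which makes it the second step of modest size in the series, after a 2.2-fold lower number from compound 1 to compound 3 (0.35 log units; beyond the scatter), and both of these steps start from the 4-methylphenyl compound. No measurement at hand explains any of these steps.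

Open is whether 3-hydroxyphenyl or 3-methylphenyl would track 3-methoxyphenyl, since the compounds shown do not compare hydroxy, methoxy and methyl at that place on the phenyl as a set. Also open, on these data alone, is whether a different kind of group on this phenyl, such as an amine, a carboxylic acid or a longer chain like butoxy, would move the number further than the small steps seen so far.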